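Trading a Formylphenyl Arm for a Naphthalenyl Arm

The source may report more compounds than this note shows. Statements on the series, on what has been measured and on what is new or still open speak of the compounds shown alone.

Measured so far:
compound 1 `Brc1cn2ccnc2c(-c2ccc3ncn(C4CCCCC4)c3c2)n1`: 24.2%
compound 2 `O=Cc1ccc(-c2cn3ccnc3c(-c3ccc4ncn(C5CCCCC5)c4c3)n2)cc1`: 51.2%

In a functional assay on MDA-MB-231 cells (Homo sapiens) for inhibition, read by sulforhodamine B assay, with a stated time of 48 h, tested at 10 uM (a lower number here means less inhibition, a higher number more inhibition at the concentration tested (going by the name of the read-out)), compound 2 gives 51.2%, the higher of the two numbers. Compound 1 gives 24.2%, and the step of a number 27 percentage points higher from compound 1 to compound 2 (beyond the scatter) is the only measured one. Compound 3 `c1ccc2c(-c3cn4ccnc4c(-c4ccc5ncn(C6CCCCC6)c5c4)n3)cccc2c1` has not been measured; it differs from compound 2 by naphthalen-1-yl in place of 4-formylphenyl on an aromatic carbon. The measured step replaced bromo with an aryl group rather than one aryl group with another, so it bears only loosely here. Compound 3 is therefore expected to sit near compound 2, with a step of a number 6.2 percentage points lower from compound 2 to compound 3 (within the scatter). The estimate for compound 3 is 45%, within 20% to 70%.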

Compound 3, a percentage reported as inhibition, at one concentration (the size of the read-out at that concentration, not a potency): 20.8%
The estimate for compound 3 lay 24.2 percentage points above the measured number; measured number inside the range.
By their numbers in this assay, from the lowest: compounds 3 and 1 (each within the scatter of the next); then compound 2.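

In this assay, naphthalen-1-yl in place of 4-formylphenyl on this aromatic carbon gives a number 30.4 percentage points lower from compound 2 to compound 3 (beyond the scatter), so not every aryl group here matches compound 2. Naphthalen-1-yl in place of bromo gives a number 3.4 percentage points lower from compound 1 to compound 3 (within the scatter), which leaves compound 1 and compound 3 indistinguishable. No available evidence accounts for the difference between the two aryl groups. Still open, as far as these compounds go, is whether the formyl group or the single phenyl ring matters more, and how a plain phenyl ring, or a phenyl ring carrying a carboxylic acid or an amine in place of formyl, would compare.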